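Swapping ethyl for 4-fluorophenyl on an amide-type nitrogen

The compounds below may be only part of what the source reports. "The series", "measured", "known", "first", "only" and "open" are said of these compounds alone.

Measured in a functional assay on A2780 cells (Homo sapiens) for cytotoxicity; on this read-out higher numbers stand for weaker inhibition and lower numbers for stronger inhibition:
- compound 1 `CC(C)C(=O)Nc1ncc(SCc2ncc(C(C)(C)C)o2)s1`: 50 nM
- compound 2 `CC(C)OC(=O)Nc1ncc(SCc2ncc(C(C)(C)C)o2)s1`: 640 nM
- compound 3 `CCNC(=O)Nc1ncc(SCc2ncc(C(C)(C)C)o2)s1`: 120 nM

Compound 3, at 120 nM, sits in the middle of these three numbers. The gaps that place it there are a 2.4-fold higher number from compound 1 to compound 3 (0.38 log units; beyond the scatter) and a 5.3-fold lower number from compound 2 to compound 3 (0.73 log units; beyond the scatter).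

The next molecule is compound 4 `CC(C)(C)c1cnc(CSc2cnc(NC(=O)Nc3ccc(F)cc3)s2)o1`. It keeps the shared core of compound 3 and differs in one place: 4-fluorophenyl in place of ethyl on an amide-type nitrogen. In words, 4-fluorophenyl stands in place of ethyl on an amide-type nitrogen.

Among the compounds with values here, no measured step makes this exact change. The closest evidence comes from swaps of the group on a carbonyl carbon, which is the same end of the molecule. The largest of these is a 13-fold higher number from compound 1 to compound 2 (1.11 log units; beyond the scatter), while the two steps given above are modest. All three go beyond the scatter, so a real shift in this assay seems likely for compound 4 as well. Its direction cannot be read from these data, so only a modest lean towards a higher number, meaning weaker inhibition, is expected. The expected change is a 1.7-fold higher number from compound 3 to compound 4 (0.22 log units; within the scatter). For compound 4 the estimated value is 200 nM, with an expected range from 50 nM to 800 nM.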

Compound 4, half-maximal inhibitory concentration: 900 nM
The estimate for compound 4 lay 4.5-fold (0.65 log units) below the measured number, outside the stated range (above it).
By their numbers in this assay, from the lowest: compound 1; then compound 3; then compounds 2 and 4 (each within the scatter of the next).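

Until now, every change at this end of the molecule had swapped the whole group on the carbonyl carbon, and compound 4 shows that in this assay the group on the amide-type nitrogen also counts: 4-fluorophenyl in place of ethyl gives a 7.5-fold higher number from compound 3 to compound 4 (0.88 log units; beyond the scatter) and so takes away much of what compound 3 had kept. The wider comparison gives an 18-fold higher number from compound 1 to compound 4 (1.26 log units; beyond the scatter), the largest step among these four compounds, whereas a 1.4-fold higher number from compound 2 to compound 4 (0.15 log units; within the scatter) leaves compound 2 and compound 4 indistinguishable, so swapping the isopropoxy group for (4-fluorophenyl)amino makes no clear difference on this read-out. The data shown offer no explanation for the shift caused by this change at the nitrogen.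

Going by these compounds, what a plain phenyl group on the same nitrogen would give remains open, so the separate contributions of the ring and its fluorine cannot be told apart. On these data alone, it is also open whether a longer chain such as butyl, or a chain ending in an amine such as 2-aminoethyl, would stay close to compound 3 or move towards compound 4.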